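The compounds below may be only part of what the source reports. "The series", "measured", "known", "first", "only" and "open" are said of these compounds alone.

In an assay on CHO cells for positive allosteric modulation of metabotropic glutamate receptor 5 (Homo sapiens), read by FLIPR (a higher number here means that more compound is needed for the effect, a lower number that less compound is needed), compound 2 `O=C(Nc1ccc(Cl)cc1CN1C(=O)c2ccccc2C1=O)c1cccnc1` gives 35000 nM, the highest of the two numbers recorded so far. The nearest neighbour, compound 1 `Cc1ccc2c(c1C)C(=O)N(Cc1cc(Cl)ccc1NC(=O)c1ccccn1)C2=O`, gives 2200 nM in this assay, and that gap lies beyond the scatter. Compound 3 `O=C(Nc1ccc(Cl)cc1CN1C(=O)c2ccccc2C1=O)c1cccnn1` has not yet been measured. Against compound 2, compound 3 carries one change: pyridazin-3-yl in place of pyridin-3-yl on a carbonyl carbon. For the measured compounds named here, no measured pair shows this change, so its effect is unknown. In this assay the expected step is a 1.2-fold lower number from compound 2 to compound 3 (0.07 log units; within the scatter), nothing beyond the scatter in either direction. Compound 3 is therefore estimated at 30000 nM, with a range from 8000 nM to 100000 nM.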

Compound 3, half-maximal effective concentration: > 100000 nM
Compound 3 was reported as a limit (the forecaster's own chance of this, stated with the estimate: 20%); middle value at least 3.3-fold (0.52 log units) from the limit.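

This change, pyridazin-3-yl in place of pyridin-3-yl on a carbonyl carbon, gives an at least 2.8-fold higher number from compound 2 to compound 3 (0.45 log units; beyond the scatter), the first step read at this place, and shows that the number in this assay responds to the make-up of this ring. In this assay compound 3 gives > 100000 nM, which is a limit of the assay and not a number. The full size of the step therefore stays unknown: the limit of > 100000 nM in this assay, at which 1 of the 3 values shown sits.

From the compounds shown here alone, it remains open whether phenyl, pyrimidin-5-yl or a saturated piperidine on the same carbonyl carbon would give a lower number than compound 2. Going by these compounds, it also remains open whether this step would hold on the core of compound 1.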